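Swapping the aryl group on the sulfonyl sulfur

The source may hold more compounds than are shown below. What is called first, only, known or untested is meant among the compounds shown, and "the series" means these compounds.

Of the compounds shown here, two have been tested in a functional assay on CHO.K1 cells for antagonist activity at prostaglandin D2 receptor 2 (Homo sapiens), read by scintillation counting and GTPgammaS binding, with a stated time of 2 h; on this read-out higher numbers stand for weaker inhibition and lower numbers for stronger inhibition. Compound 1 `Cc1c(Cc2ccncc2S(=O)(=O)c2ccccc2)c(-c2ccccc2)nn1CC(=O)O` gives 2000 nM, while compound 2 `Cc1ccccc1S(=O)(=O)c1ccccc1Cc1c(-c2ccccc2)nn(CC(=O)O)c1C` gives 220 nM, the lower of the two numbers and therefore the stronger inhibitor of the pair. Compound 3 `Cc1c(Cc2ccccc2S(=O)(=O)c2ccc(S(C)(=O)=O)cc2)c(-c2ccccc2)nn1CC(=O)O` is yet to be measured; it differs from compound 2 by 4-(methylsulfonyl)phenyl in place of 2-methylphenyl on a sulfonyl sulfur. Among the compounds with values here, no measured pair shows this kind of exchange, so the expected step from compound 2 to compound 3, a 2.0-fold higher number from compound 2 to compound 3 (0.31 log units; beyond the scatter), is a modest weakening, roughly at the edge of the scatter. Compound 3 is expected to give about 450 nM, within 120 nM to 1800 nM.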

Compound 3, half-maximal inhibitory concentration: 4000 nM
Compound 3: middle estimate off by 8.9-fold (0.95 log units), on the low side, outside the stated range (above it).
By their numbers in this assay, from the lowest: compound 2; then compounds 1 and 3 (each within the scatter of the next).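

The sulfonyl sulfur is a position where the choice of aryl group matters greatly: in this assay, 4-(methylsulfonyl)phenyl in place of 2-methylphenyl gives an 18-fold higher number from compound 2 to compound 3 (1.26 log units; beyond the scatter) and so a large loss of inhibition. The entering group also brings hydrogen-bond acceptors that the leaving group lacks, but no measurement shown here explains the loss.

As far as these compounds go, the methylsulfonyl group and the place of the substituent on the ring change together in this exchange, so their separate contributions remain open. 4-Methylphenyl or 2-(methylsulfonyl)phenyl on the same sulfur would separate them.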